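Moving a Methyl on the Aryl Amine of Two Cores

A few compounds are considered here, and "the series" means these few. Any claim that something is new, unique, unknown or untested is made for them only; others in the source may bear on it.

Three compounds were measured in a functional assay on the whole organism (strain Wistar) for inhibition, with Rattus norvegicus as the target, read by paw edema, with stated times of 1 h and 3 h, at a dose of 200 mg/kg by the oral route; a higher number here means more inhibition at the dose given (going by the name of the read-out), a lower number less inhibition:
Compound 1, `Cc1ccc(/C=C2\CCCC(CN(C)c3ccc(C)cc3)C2=O)cc1`: 38.3%
Compound 2, `Cc1ccc(/C=C2\CCCC(CN(C)c3cccc(C)c3)C2=O)cc1`: 36.2%
Compound 3, `Cc1ccc(N(C)CC2CCC/C(=C\c3ccccc3)C2(O)c2ccccc2)cc1`: 59.6%

Compound 1 and compound 2 share one core. The difference between them is 3-methylphenyl in place of 4-methylphenyl on an amine nitrogen, and it made a step of a number 2.1 percentage points lower from compound 1 to compound 2 (within the scatter). Compound 3 is built on another core; how the core of compound 3 differs from the core of compound 1 is not broken down here. In this assay compound 3 stands highest of the three, with the values of compound 1 and compound 2 both lying beyond the scatter below it.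

Compound 4, `Cc1cccc(N(C)CC2CCC/C(=C\c3ccccc3)C2(O)c2ccccc2)c1`, has not yet been measured in this assay. It differs from compound 3 by 3-methylphenyl in place of 4-methylphenyl on an amine nitrogen. This is the same change as the one from compound 1 to compound 2, made at the same place, so that among the compounds shown it occurs twice in all.

Because the earlier step of a number 2.1 percentage points lower from compound 1 to compound 2 (within the scatter) lay within the scatter, the step on the core of compound 3 is expected to be small as well. The expected step is a number 2.1 percentage points lower from compound 3 to compound 4 (within the scatter), and it rests on that single earlier instance only, which is a thin basis. Compound 4 is thus estimated at 57.5%, with a range of 47% to 66%.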

Compound 4, a percentage reported as inhibition, in the whole organism at one dose (the size of the read-out at that dose, not a potency): 36.2%
Beside the measured number, compound 4's estimate is 21.3 percentage points above it; measured number below the stated range.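

On the core of compound 3, 3-methylphenyl in place of 4-methylphenyl on the amine nitrogen gave a number 23.4 percentage points lower from compound 3 to compound 4 (beyond the scatter) in this assay, so the step seen on the core of compound 1 did not carry over in size to this second core: the same change on two cores in this assay, a number 2.1 percentage points lower (within the scatter) from compound 1 to compound 2 and a number 23.4 percentage points lower (beyond the scatter) from compound 3 to compound 4, 21.3 percentage points apart, beyond the scatter of two such steps. Among the compounds shown, the effect of this change therefore depends on the core it is made on, and the step on one core would not have served as a reliable guide to the step on the other. This does not show which structural difference between the two cores accounts for the gap, nor does it establish a general rule for the series, as the comparison rests on a single pair on each core, read at one dose.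

The compounds shown leave open whether the outcome on the core of compound 3 is specific to the methyl group, or whether a chloro or methoxy group in its place, or a plain phenyl without any such group, would show the same dependence on the core. From the compounds shown here alone, it also remains open how a longer chain in place of the methyl on the amine nitrogen would behave on either core.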